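A few compounds are considered here, and "the series" means these few. Any claim that something is new, unique, unknown or untested is made for them only; others in the source may bear on it.

Measured compounds:
Compound 1 `Cc1cccc(C)c1Oc1cc(Nc2ccc(C#N)cc2)ncc1[N+](=O)[O-]`: 126000 nM
Compound 2 `N#Cc1ccc(Nc2cc(Oc3c(Cl)cc(Cl)cc3Cl)c([N+](=O)[O-])cn2)cc1`: 16200 nM
Compound 3 `Cc1cc(Br)c(Oc2cc(Nc3ccc(C#N)cc3)ncc2[N+](=O)[O-])c(Br)c1`: 23600 nM

In an ADME assay on MT4 cells (Homo sapiens) for inhibition, read by MTT assay, with a stated time of 5 days (on this read-out higher numbers stand for lower toxicity in this test and lower numbers for higher toxicity in this test), compound 1 stands highest of the three numbers, with compound 3 nearest and compound 2 furthest from it. The step of a 7.8-fold lower number from compound 1 to compound 2 (0.89 log units; beyond the scatter) and the step of a 5.3-fold lower number from compound 1 to compound 3 (0.73 log units; beyond the scatter) both go beyond the scatter and both move downward; between the two halogenated compounds the step of a 1.5-fold higher number from compound 2 to compound 3 (0.16 log units; within the scatter) lies within the scatter.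

Compound 4 `N#Cc1ccc(Nc2cc(Oc3c(F)cc(F)cc3F)c([N+](=O)[O-])cn2)cc1` differs from compound 1 in one place: 2,4,6-trifluorophenyl in place of 2,6-dimethylphenyl on an oxygen on an aromatic ring. The two measured steps that bear on this change are those from compound 1 to compound 2 and from compound 1 to compound 3, where a halogenated ring took the place of the 2,6-dimethylphenyl ring and the number fell by a modest amount in each case. Whether the trifluoro ring behaves like the trichloro and dibromo rings cannot be read from these three compounds alone, so the expected step is placed smaller than either measured one, but still downward: compound 4 is expected to show a 2.5-fold lower number from compound 1 to compound 4 (0.40 log units; beyond the scatter). The estimate for compound 4 in this assay is 50000 nM, with a range from 15000 nM to 160000 nM.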

Compound 4, half-maximal cytotoxic concentration: 3540 nM
Beside the measured number, compound 4's estimate is 14-fold (1.15 log units) above it; the whole stated range lies above it.
By their numbers in this assay, from the lowest: compound 4; then compounds 2 and 3 (each within the scatter of the next); then compound 1.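

In this assay the 2,4,6-trifluorophenyl group on the oxygen brings a large step, a 36-fold lower number from compound 1 to compound 4 (1.55 log units; beyond the scatter) and so reaches further down than the modest steps seen with the other halogenated rings. The three halogenated rings therefore do not share one level at this place: the step of a 4.6-fold lower number from compound 2 to compound 4 (0.66 log units; beyond the scatter) and the step of a 6.7-fold lower number from compound 3 to compound 4 (0.82 log units; beyond the scatter) both lie beyond the scatter, whereas compounds 2 and 3 remain within the scatter of each other. Exchanging the chlorines of compound 2 for fluorines thus matters here, and the number in this test depends on which halogen the ring carries.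

Going by these compounds, how a ring bearing a methoxy group or a single fluorine, or an amine in place of the oxygen, would read in this test stays open. Nothing given here accounts for the size of the fall at this change.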